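The source may hold more compounds than are shown below. What is called first, only, known or untested is meant among the compounds shown, and "the series" means these compounds.

Measured in an assay on HL-60 cells for agonist activity at vitamin D3 receptor (Homo sapiens), read by microscopy, with a stated time of 96 h; on this read-out higher numbers stand for an effect only at larger amounts of compound and lower numbers for an effect already at smaller amounts:

Compound 1 `CCOC(=O)CN(C)C(=O)c1ccc(C(CC)(CC)c2ccc(OCC(=O)C(C)(C)C)c(C)c2)n1CC` gives > 50000 nM, which is a limit of the assay (the limit of > 50000 nM in this assay, at which 1 of the 3 values shown sits).
Compound 2 `CCn1c(C(=O)N(CCC#N)CCC#N)ccc1C(CC)(CC)c1ccc(OCC(=O)C(C)(C)C)c(C)c1` gives 870 nM.
Compound 3 `CCOC(=O)CN(C)C(=O)c1ccc(C(CC)(CC)c2ccc(OCC(O)C(C)(C)C)c(C)c2)n1CC` gives 210 nM.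

Compound 3 stands with the lowest of the two numbers in this assay; the nearest is compound 2, whose number is higher by a gap beyond the scatter, and the remaining value is a limit.

Compound 4 `C#CCNC(=O)c1ccc(C(CC)(CC)c2ccc(OCC(O)C(C)(C)C)c(C)c2)n1CC` is not yet measured. It differs from compound 3 in one place: propargylamino in place of ((ethoxycarbonyl)methyl)(methyl)amino on a carbonyl carbon. The amide nitrogen thus loses its methyl and ester-bearing substituents and carries a single propargyl group with a free amide hydrogen.

Among the measured compounds shown here, two measured steps bear on this. The change at the same carbonyl carbon, an at least 57-fold lower number from compound 1 to compound 2 (1.75 log units; beyond the scatter), shows that exchanging the amide substituents can move the number a long way in this series. The other step, an at least 230-fold lower number from compound 1 to compound 3 (2.37 log units; beyond the scatter), concerns the side chain on the aromatic oxygen, which compound 3 and compound 4 share. Both steps show that this assay responds strongly to single changes, but neither tells the direction for a propargylamino group. A step of some size in this assay is therefore expected, with the direction open, so the estimate for compound 4 is kept close to compound 3 with a wide range: 150 nM, between 30 nM and 1000 nM, meaning an expected step of a 1.4-fold lower number from compound 3 to compound 4 (0.15 log units; within the scatter).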

Compound 4, half-maximal effective concentration: 240 nM
Estimate against measurement, compound 4: 1.6-fold (0.20 log units) below; measured number inside the range.
By their numbers in this assay, from the lowest: compounds 3 and 4 (each within the scatter of the next); then compound 2. At a limit, above all of these: compound 1.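

In this assay, the amide substituent on this carbonyl carbon can be exchanged for a much smaller one without a readable shift: a 1.1-fold higher number from compound 3 to compound 4 (0.06 log units; within the scatter). Going from 8 heavy atoms to 4, losing the ester, gaining an amide hydrogen and bringing in a triple bond therefore leave the number within the scatter, so neither the ester nor the fully substituted amide nitrogen is required for a number of this size while the 1-hydroxy-2,2-dimethylpropyl side chain is present. The earlier step at this carbonyl carbon started from a limit and carried the (tert-butyl)carbonyl side chain, whereas this one joins two measured numbers with the hydroxy side chain in place, although nothing measured here accounts for the flat step.

On these data alone, it remains open whether the triple bond or the amide hydrogen contributes anything, which a plain propyl amide, a dimethyl amide or an unsubstituted primary amide would help to separate. Also open, as far as these compounds go, is how far this position reaches, for example with a carboxylic acid, a morpholine amide or a longer alkyne chain, and whether propargylamino behaves alike alongside the (tert-butyl)carbonyl side chain.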